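Benzoxazolyl for pyrrolyl: working notes on compound 4

The source may report more compounds than this note shows. Statements on the series, on what has been measured and on what is new or still open speak of the compounds shown alone.

Measured compounds in a toxicity assay on NIH3T3 cells (Mus musculus) for cytotoxicity, read by resazurin assay; on this read-out higher numbers stand for an effect only at larger amounts of compound and lower numbers for an effect already at smaller amounts:
compound 1 `COC(=O)c1ccc(NCc2cncn2Cc2ccccc2Cl)cc1-c1ccccc1` gives 10000 nM.
compound 2 `COC(=O)c1ccc(NCc2cncn2Cc2ccc(N)cc2)cc1-c1ccccc1` gives only the assay limit > 10000 nM.
compound 3 `c1ccc(-c2ccc(Cn3cncc3CNc3ccc(-c4ccc[nH]4)c(-c4ccccc4)c3)cc2)cc1` gives only the assay limit > 10000 nM.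

Compound 3 thus stands at the limit, the same limit at which compound 2 sits (the limit of > 10000 nM in this assay, at which 2 of the 3 values shown sit); only compound 1 yields a number. Compound 4 `c1ccc(-c2ccc(Cn3cncc3CNc3ccc(-c4nc5ccccc5o4)c(-c4ccccc4)c3)cc2)cc1` differs from compound 3 by 1,3-benzoxazol-2-yl in place of 1H-pyrrol-2-yl on an aromatic carbon. Among the measured compounds shown here, the single measured step, a number no lower from compound 1 to compound 2 (the limit leaves the size open), changes a group on a saturated chain carbon bound to an aromatic nitrogen and ends at the limit; its size is not readable, and it does not touch the position altered in compound 4. The step of a number no higher from compound 3 to compound 4 (the limit leaves the size open) is therefore expected to remain within the scatter. Compound 4 is estimated at 10000 nM in this assay, in the range 4000 nM to 30000 nM, most likely reported again as a limit.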

Compound 4, half-maximal effective concentration: > 10000 nM
Compound 4 gave a limit, no number (the forecaster's own chance of this, stated with the estimate: 65%); the middle value sits exactly at the limit.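

Among the compounds shown here, compound 3 and compound 4 both give a limit rather than a number, so no step between them can be read. The compounds shown leave open whether 1,3-benzoxazol-2-yl in place of 1H-pyrrol-2-yl changes the read-out at all.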